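Extending the Amide Chain on the Oxolanyl Ether

The compounds below may be only part of what the source reports. "The series", "measured", "known", "first", "only" and "open" are said of these compounds alone.

Three analogues sharing one core have been tested in a functional assay on PC-3 cells (Homo sapiens) for antiproliferative activity, read by MTT assay, with a stated time of 72 h; a lower number here means a stronger inhibitor, a higher number a weaker inhibitor. Compound 1 `C/C=C/C(=O)Nc1cc2c(N3CCc4ccccc43)ncnc2cc1OC` gives 8120 nM. Compound 2 `CCC/C=C/C(=O)Nc1cc2c(N3CCc4ccccc43)ncnc2cc1OC` gives 4240 nM, and compound 3 `C/C=C/C(=O)Nc1cc2c(N3CCc4ccccc43)ncnc2cc1O[C@@H]1CCOC1` gives 5220 nM. Compound 3 stands second highest of the three numbers, nearest compound 2 and furthest from compound 1, with both gaps within the scatter. Compound 4 `CCC/C=C/C(=O)Nc1cc2c(N3CCc4ccccc43)ncnc2cc1O[C@@H]1CCOC1` differs from compound 3 by ethyl in place of hydrogen on a saturated chain carbon bound to a double-bonded chain carbon. Among the compounds with values here, the one measured step that bears on this change is a 1.9-fold lower number from compound 1 to compound 2 (0.28 log units; within the scatter), the same exchange made on the methyl ether. The reader of these numbers therefore expects a step of similar size in this assay, a 1.7-fold lower number from compound 3 to compound 4 (0.24 log units; within the scatter), toward a lower number but not clearly beyond the scatter. Compound 4 is estimated at 3000 nM, within 1200 nM to 8000 nM.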

Compound 4, half-maximal inhibitory concentration: 9230 nM
Beside the measured number, compound 4's estimate is 3.1-fold (0.49 log units) below it, outside the stated range (above it).
By their numbers in this assay, from the lowest: compounds 2, 3, 1 and 4 (each within the scatter of the next, the first and the last beyond it).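

In this assay, ethyl in place of hydrogen on a saturated chain carbon bound to a double-bonded chain carbon does not carry over from the methyl ether to the oxolan-3-yl ether, with a 1.8-fold higher number from compound 3 to compound 4 (0.25 log units; within the scatter), so the outcome of this change depends on the ether: the same change on two cores in this assay, a 1.9-fold lower number (0.28 log units; within the scatter) from compound 1 to compound 2 and a 1.8-fold higher number (0.25 log units; within the scatter) from compound 3 to compound 4, 3.4-fold (0.53 log units) apart, beyond the scatter of two such steps. Seen from the other side, oxolan-3-yl in place of methyl on an oxygen on an aromatic ring depends on the amide chain, with a 2.2-fold higher number from compound 2 to compound 4 (0.34 log units; beyond the scatter), the one step here beyond the scatter: the same change on two cores in this assay, a 1.6-fold lower number (0.19 log units; within the scatter) from compound 1 to compound 3 and a 2.2-fold higher number (0.34 log units; beyond the scatter) from compound 2 to compound 4, 3.4-fold (0.53 log units) apart, beyond the scatter of two such steps. The four compounds leave open whether a dimethylamino group in place of the ethyl would show the same dependence on the ether.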